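Chain length and tolerated concentration in a cytotoxicity assay

A few compounds are considered here, and "the series" means these few. Any claim that something is new, unique, unknown or untested is made for them only; others in the source may bear on it.

Measured so far:
compound 1, `CCCCCCNc1cnc(C(=O)NCc2ccccc2)cn1`: >= 100000 nM (a limit)
compound 2, `CCCCCCCCNc1cnc(C(=O)NCc2ccccc2)cn1`: 20000 nM
compound 3, `CCCCCCCNc1nccnc1C(=O)NCc1ccccc1`: > 100000 nM (a limit)

Compounds 1 and 2 share one core; compound 3 has another, and the difference between the two cores is not broken down here. In an ADME assay on Vero cells (Chlorocebus sabaeus) for cytotoxicity, read by microscopy, with a stated time of 6 days (a lower number here means that less compound is tolerated, a higher number that more compound is tolerated), compound 2 gives 20000 nM. The value of compound 1 is a limit of this assay, the one in the limit of >= 100000 nM in this assay, at which 1 of the 3 values shown sits. The change hydrogen in place of ethyl on a saturated chain carbon, six bonds along the chain from a nitrogen on an aromatic ring thus produced an at least 5.0-fold higher number from compound 2 to compound 1 (0.69 log units; beyond the scatter). The value of compound 3 is also a limit, that in the limit of > 100000 nM in this assay, at which 1 of the 3 values shown sits.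

Compound 4, `CCCCCNc1nccnc1C(=O)NCc1ccccc1`, differs from compound 3 by hydrogen in place of ethyl on a saturated chain carbon, five bonds along the chain from a nitrogen on an aromatic ring. This is the same kind of change as from compound 2 to compound 1, not the same: its place is five bonds, rather than six bonds, along the chain from a nitrogen on an aromatic ring. A step of about a number no higher from compound 3 to compound 4 (the limit leaves the size open) is expected, which cannot be read as a number because compound 3 already sits at the limit in the limit of > 100000 nM in this assay, at which 1 of the 3 values shown sits. Compound 4 is therefore estimated at 100000 nM, between 50000 nM and 200000 nM, most likely again reported only as a limit.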

Compound 4, minimum cytotoxic concentration: > 100000 nM
Compound 4: only a limit was reported; the forecaster's own chance of this, stated with the estimate: 85%; the middle value lies on the limit itself.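

In this assay compound 4 gives > 100000 nM, which is a limit, and the value of compound 3 is a limit too; the step from compound 3 to compound 4 cannot be read. The compounds shown leave open whether hydrogen in place of ethyl changes the tolerated concentration on this core at all.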